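A few compounds are considered here, and "the series" means these few. Any claim that something is new, unique, unknown or untested is made for them only; others in the source may bear on it.

In a functional assay (aorta) with Oryctolagus cuniculus as the target (on this read-out lower numbers stand for tighter binding and higher numbers for weaker binding), compound 1 (`CCc1ccc(OCCCN2CCC(C(c3ccc(F)cc3)c3ccc(F)cc3)CC2)c(OC)c1`) gives 2.51 nM and compound 2 (`Fc1ccc(C(c2ccc(F)cc2)C2CCN(CCCOc3ccc(Br)cc3)CC2)cc1`) gives 1.59 nM. These two numbers lie within the scatter of each other, so compound 2 stands level with compound 1. Compound 3 (`COc1ccc(OCCCN2CCC(C(c3ccc(F)cc3)c3ccc(F)cc3)CC2)cc1`) keeps the core of compound 2 and differs in one place: methoxy in place of bromo on an aromatic carbon. This is methoxy in place of bromo on an aromatic carbon, para to a large group. For the measured compounds named here, no measured step isolates this exchange. The only one that bears on it is a 1.6-fold lower number from compound 1 to compound 2 (0.20 log units; within the scatter), where 4-bromophenyl took the place of 4-ethyl-2-methoxyphenyl, and it stayed within the scatter. No change beyond the scatter is therefore expected in this assay, and the estimated 1.3-fold higher number from compound 2 to compound 3 (0.10 log units; within the scatter) stays small. Compound 3 is expected at 2 nM, with an estimated range of 0.8 nM to 5 nM.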

Compound 3, dissociation constant: 2.51 nM
Compound 3: middle estimate off by 1.3-fold (0.10 log units), on the low side; the measured number falls inside the stated range.
By their numbers in this assay, from the lowest: compounds 2, 1 and 3 (each within the scatter of the next).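

In this assay, the exchange of bromo for methoxy on this aromatic carbon now has a step of its own, a 1.6-fold higher number from compound 2 to compound 3 (0.20 log units; within the scatter), whereas the earlier step changed the whole aryl group at once. Putting 4-methoxyphenyl in place of 4-ethyl-2-methoxyphenyl gives no change at the digits printed from compound 1 to compound 3 (within the scatter), so all three aryl groups shown on this oxygen remain within the scatter of one another in this assay. Nothing measured here offers an explanation for these numbers.

What the compounds shown leave open is whether a group of a different kind on this aromatic carbon, such as an amine or a carboxylic acid, would also stay within the scatter. Also open, on these data alone, is whether a longer chain in place of methoxy would do the same.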